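Swapping a Nitro Arm for a Chloro Arm

The source may hold more compounds than are shown below. What is called first, only, known or untested is meant among the compounds shown, and "the series" means these compounds.

Measured so far:
compound 1 `COc1ccc(C(=O)/C=C/c2ccc(N3CCCC3)cc2)c2c1C=CC(C)(C)O2` — 7370 nM
compound 2 `COc1ccc(C(=O)/C=C/c2ccc([N+](=O)[O-])cc2)c2c1C=CC(C)(C)O2` — 3420 nM

In a functional assay on SK-OV-3 cells (Homo sapiens) for antiproliferative activity, read by MTT assay, with a stated time of 24 h (on this read-out lower numbers stand for stronger inhibition and higher numbers for weaker inhibition), compound 1 gives 7370 nM, while compound 2 gives 3420 nM. For the measured compounds named here, the only measured step, a 2.2-fold lower number from compound 1 to compound 2 (0.33 log units; beyond the scatter), puts compound 2 at the lowest of the two numbers, with compound 1 as its nearest neighbour.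

Compound 3 `COc1ccc(C(=O)/C=C/c2ccccc2Cl)c2c1C=CC(C)(C)O2` differs from compound 2 in one place: 2-chlorophenyl in place of 4-nitrophenyl on a double-bonded chain carbon bound to a double-bonded chain carbon. Going by the values given here, the measured step from compound 1 to compound 2 bears on this only loosely, since it shows that bringing the nitro group onto the shared core gave the modest gain a 2.2-fold lower number from compound 1 to compound 2 (0.33 log units; beyond the scatter); compound 3 gives that group up again and gains a chlorine on a different ring carbon, for which no measured pair exists. A modest move back toward the number of compound 1 seems the most likely outcome, but it could equally stay within the scatter. Compound 3 is therefore expected to give about 5500 nM, with a plausible range from 2000 nM to 15000 nM. That expectation amounts to a step of a 1.6-fold higher number from compound 2 to compound 3 (0.21 log units; within the scatter).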

Compound 3, half-maximal inhibitory concentration: > 10000 nM
Compound 3 was reported as a limit; the forecaster's own chance of this, stated with the estimate: 10%; at least 1.8-fold (0.25 log units) between middle value and limit.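

For the compounds shown here, replacing 4-nitrophenyl with 2-chlorophenyl on a double-bonded chain carbon bound to a double-bonded chain carbon brings an at least 2.9-fold higher number from compound 2 to compound 3 (0.46 log units; beyond the scatter), so in this assay this place on the molecule is one where a swap can cost activity, whereas the only earlier step, a 2.2-fold lower number from compound 1 to compound 2 (0.33 log units; beyond the scatter), was a gain. Compound 3 gives > 10000 nM, which is a limit of the assay and not a number. The step therefore has a known minimum but no known maximum, because the reading ends at a limit: the limit of > 10000 nM in this assay, at which 1 of the 3 values shown sits.

This swap changes two things at once, the substituent and the ring carbon that carries it, and the compounds shown cannot say which of the two accounts for the loss. Also open, on these data alone, is how the arm behaves with a bare phenyl ring, or with a ring carrying a carboxylic acid or a trifluoromethyl group, and whether any of these would give a lower number than compound 2 does at 3420 nM.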